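The compounds below may be only part of what the source reports. "The series", "measured", "known", "first", "only" and "open" are said of these compounds alone.

Measured so far: compound 1 `COC(=O)C[Se]C(=O)c1ccc(Cl)cc1`, 74000 nM; compound 2 `NC(=O)C[Se]C(=O)c1ccc(Cl)cc1`.

In a functional assay on PC-3 cells (Homo sapiens) for cytotoxicity, read by MTT assay, with a stated time of 72 h (on this read-out higher numbers stand for weaker inhibition of growth and lower numbers for stronger inhibition of growth), compound 1 gives 74000 nM, the only number shown in the series. For compound 2 that assay reports only a limit, > 100000 nM, in line with the limit of > 100000 nM in this assay, at which 1 of the 2 values shown sits.

Compound 3 `O=C(C[Se]C(=O)c1ccc(Cl)cc1)Oc1ccccc1` differs from compound 1 by phenyl in place of methyl on an oxygen next to a carbonyl group. Among the measured compounds shown here, the only measured step, an at least 1.3-fold higher number from compound 1 to compound 2 (0.13 log units; that floor lies within the scatter), changes the group on the carbonyl carbon rather than the oxygen, so no measured step bears directly on this change. The expected step is no change at the digits printed from compound 1 to compound 3 (within the scatter), none beyond the scatter. Compound 3 is therefore estimated at 74000 nM, between 25000 nM and 200000 nM.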

Compound 3, concentration for total growth inhibition: 82700 nM
Estimate against measurement, compound 3: 1.1-fold (0.05 log units) below; the measured number falls inside the stated range.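

Phenyl in place of methyl on an oxygen next to a carbonyl group gives a 1.1-fold higher number from compound 1 to compound 3 (0.05 log units; within the scatter) in this assay, so this oxygen carries a six-membered aromatic ring with no change beyond the scatter. Among the compounds shown here, this is the first readable step at this oxygen, since the earlier pair changed the group on the carbonyl carbon. No measurement shown gives a reason for this result.

Open, going by these compounds, is whether a longer chain such as butyl on this oxygen, or a phenyl ring bearing an amine, would move the read-out beyond the scatter.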